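Notes on a pyridinone series: benzylic substituent and potency

The source may hold more compounds than are shown below. What is called first, only, known or untested is meant among the compounds shown, and "the series" means these compounds.

Measured so far in an assay for inhibition of MAP kinase-interacting serine/threonine-protein kinase 2 (Homo sapiens), read by luminescence and ADP-Glo, with a stated time of 2 h; a lower number here means a stronger inhibitor, a higher number a weaker inhibitor:
compound 1 `NC(=O)c1ccc(Cn2cc(-c3ccc4cn[nH]c4c3)ccc2=O)cc1`: compound 1 gives > 2000 nM.
compound 2 `Cn1cc2ccc(-c3ccc(=O)n(Cc4ccccc4)c3)cc2n1`: compound 2 gives > 2000 nM.
compound 3 `O=c1ccc(-c2ccc3cn[nH]c3c2)cn1Cc1cccc(Cl)c1`: compound 3 gives 40 nM.

Compound 1 stands only at a limit of this assay. Compound 2 also stands only at a limit, and differs from the others in its methylated core. Of the three, only compound 3 gives a number, and it carries a chlorine on the six-membered aromatic ring of carbon only rather than the carbamoyl of compound 1. For the measured compounds named here, two of the three values sit at the limit of > 2000 nM in this assay, at which 2 of the 3 values shown sit, so no measured step is available.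

The next compound is compound 4 `O=c1ccc(-c2ccc3cn[nH]c3c2)cn1Cc1ccc(C(F)(F)F)cc1`. It differs from compound 1 in one place: trifluoromethyl in place of carbamoyl on an aromatic carbon. Compound 3 reaches 40 nM with a halogen on that ring, and on that basis the step of an at least 5.0-fold lower number from compound 1 to compound 4 (0.69 log units; beyond the scatter) is expected to go toward stronger inhibition and to lie beyond the scatter. Compound 1 gives only a limit, so the size of that expected step is uncertain. Compound 4 is estimated at 400 nM, within 60 nM to 2500 nM, with a real chance that this assay again reports only a limit.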

Compound 4, half-maximal inhibitory concentration: 1110 nM
For compound 4 the middle estimate is 2.8-fold (0.44 log units) below the measured one; the range from low to high includes it.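

In this assay compound 4 gives 1110 nM, so with trifluoromethyl para to a large group on the six-membered aromatic ring of carbon only, this position yields a number rather than a limit, and the carbamoyl is not needed for that. The change reads as an at least 1.8-fold lower number from compound 1 to compound 4 (0.25 log units; that floor lies within the scatter), which fixes a direction only as far as that floor allows and gives no true size. The step has only a floor because compound 1 stands at a limit of the assay: the limit of > 2000 nM in this assay, at which 2 of the 4 values shown sit.

Compound 3 and compound 4 differ both in the group and in where it sits on the ring, so the compounds shown do not separate the effect of the group from the effect of its place. Also open, from the compounds shown here alone, is how a chlorine, an amine, a carboxylic acid or a methoxy group would read at this same position on the shared core, and whether any of them would give a number in this assay or again only a limit.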